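Closing a Urea Chain into a Pyrrolidine Ring

A few compounds are considered here, and "the series" means these few. Any claim that something is new, unique, unknown or untested is made for them only; others in the source may bear on it.

Two measured compounds share a core. Compound 1 `Cc1cc(C(=O)N2CCCCc3ccccc32)cc(C)c1CNC(=O)Nc1c(F)cccc1F` gives 82 nM in a functional assay on HEK293 cells for agonist activity at Vasopressin V2 receptor (Homo sapiens), read by a luciferase reporter and cAMP accumulation; a higher number here means that more compound is needed for the effect, a lower number that less compound is needed. Compound 2 `COC(=O)CNC(=O)NCc1ccc(C(=O)N2CCCCc3ccccc32)cc1C` gives 37 nM in this assay, the lower of the two numbers, and its gap to compound 1 lies beyond the usual scatter. Compound 3 `COC(=O)[C@@H]1CCCN1C(=O)NCc1ccc(C(=O)N2CCCCc3ccccc32)cc1C` is compound 2 with one change: 2-(methoxycarbonyl)pyrrolidin-1-yl in place of ((methoxycarbonyl)methyl)amino on a carbonyl carbon. Among the measured compounds shown here, no measured pair shows this change, so its effect is unknown here. The step of a 1.9-fold higher number from compound 2 to compound 3 (0.28 log units; within the scatter) is expected to be small, toward a somewhat higher number. Compound 3 is therefore estimated at 70 nM, within 25 nM to 250 nM.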

Compound 3, half-maximal effective concentration: 100 nM
Beside the measured number, compound 3's estimate is 1.4-fold (0.15 log units) below it; low and high end bracket the measured number.
By their numbers in this assay, from the lowest: compound 2; then compounds 1 and 3 (each within the scatter of the next).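

Among the compounds shown here, putting 2-(methoxycarbonyl)pyrrolidin-1-yl in place of ((methoxycarbonyl)methyl)amino on this carbonyl carbon gives a 2.7-fold higher number from compound 2 to compound 3 (0.43 log units; beyond the scatter) in this assay and is the first step that can be read at this position. The change loses the hydrogen-bond donor and adds a five-membered ring and a defined stereocentre together, so this single step cannot separate their effects. Nothing available here explains the step. Still open, from the compounds shown here alone, is how the opposite stereoisomer, a six-membered piperidine ring, or a carboxylic acid in place of the methyl ester would read.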